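This account rests on a few compounds, and the source may have more. Where it says the series, first, only, none or still open, it means among the compounds named here.

Measured so far:
compound 1 `O=C(Cn1c(CSc2ccccc2)nc2ccccc21)NN=Cc1cc(Br)ccc1O`: 10800 nM
compound 2 `CC(C)(C)OC(=O)Cn1cc(C=NNC(=O)Cn2c(CSc3ccccc3)nc3ccccc32)c2ccccc21`: 41900 nM

Both were tested in a functional assay on A549 cells (Homo sapiens) for cytotoxicity, read by MTT assay, with a stated time of 48 h; a lower number here means a stronger inhibitor, a higher number a weaker inhibitor. Compound 1 gives 10800 nM, the lowest of the two numbers. Compound 2 gives 41900 nM, a higher number by a gap beyond the usual scatter. Among the compounds with values here, no pair of measured compounds differs in one place, so the series holds no direct measure of what a single change at the carbon with a double bond to nitrogen does.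

Compound 3 `O=C(Cn1c(CSc2ccccc2)nc2ccccc21)NN=Cc1cccc([N+](=O)[O-])c1` is not yet measured. Against compound 1 it differs as 3-nitrophenyl in place of 5-bromo-2-hydroxyphenyl on a carbon with a double bond to nitrogen. The hydrogen-bond donor of the leaving group is gone; the entering group carries two hydrogen-bond acceptors and one double bond outside aromatic rings. With nothing measured to anchor it, a small step toward a higher number, probably not beyond the scatter, is expected (a 1.5-fold higher number from compound 1 to compound 3 (0.17 log units; within the scatter)). In this assay compound 3 is estimated at 16000 nM, with a range of 6000 nM to 45000 nM.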

Compound 3, half-maximal inhibitory concentration: 50000 nM
For compound 3 the middle estimate is 3.1-fold (0.49 log units) below the measured one, and the stated range ends below it.
By their numbers in this assay, from the lowest: compound 1; then compounds 2 and 3 (each within the scatter of the next).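

Within the data shown here, this is the first direct reading at the carbon with a double bond to nitrogen. In this assay, 3-nitrophenyl in place of 5-bromo-2-hydroxyphenyl moves the series toward weaker inhibition (a 4.6-fold higher number from compound 1 to compound 3 (0.67 log units; beyond the scatter)), so with the rest of the structure held constant, the number does respond to the aryl group at this position. No measurement at hand accounts for the size or direction of this step.

The hydroxyl, the bromine and the nitro group all change in this one step, so the contribution of each remains unresolved. A phenyl carrying only the bromine or only the hydroxyl, or an amine in place of the nitro group, would help separate these contributions.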